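The compounds below may be only part of what the source reports. "The series", "measured", "known", "first", "only" and "open" are said of these compounds alone.

Measured compounds:
- compound 1 `Cc1nnc(SCC(=O)N/N=c2/scc(-c3ccccc3)n2-c2ccccc2)s1`: 65.9%
- compound 2 `Cc1ccc(-c2cs/c(=N/NC(=O)CSc3nnnn3-c3ccccc3)n2-c2ccccc2)cc1`: 38.8%
- compound 3 `O=C(CSc1nnnn1-c1ccccc1)N/N=c1/scc(-c2ccc(F)cc2)n1-c1ccccc1`: 49.3%

In a functional assay on C6 cells (Rattus norvegicus) for cytotoxicity, read by MTT assay, with a stated time of 24 h, tested at 25 ug/mL (a higher number here means a weaker effect of the compound at the concentration tested, a lower number a stronger effect), compound 1 gives the highest of the three numbers, that is, the weakest effect at the concentration tested. Compound 3 comes nearest to it, and its number is lower by a margin beyond the scatter; compound 2 stands furthest, lower still.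

Compound 4 `COc1ccc(-c2cs/c(=N/NC(=O)CSc3nnc(C)s3)n2-c2ccccc2)cc1` is not yet measured. It differs from compound 1 in one place: methoxy in place of hydrogen on an aromatic carbon.

Going by the values given here, no measured pair shows this exact change. Among the compounds with values here, the only measured step between compounds that differ in one place is a number 10.5 percentage points higher from compound 2 to compound 3 (beyond the scatter), where a substituent on the same six-membered ring was exchanged. That step is modest and shows that a change at this position can move the number by about that much, but it involves a fluoro and a methyl rather than a methoxy, and those two compounds carry a different heterocycle than compound 1. On this basis only a modest step in this assay is expected from compound 1 to compound 4, with no confident direction. The estimate for compound 4 is 60%, with a range from 44% to 76%, which means an expected step of a number 5.9 percentage points lower from compound 1 to compound 4 (within the scatter).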

Compound 4, a percentage reported as activity, at one concentration (the size of the read-out at that concentration, not a potency): 42.6%
Estimate against measurement, compound 4: 17.4 percentage points above; the whole stated range lies above it.
By their numbers in this assay, from the lowest: compounds 2, 4 and 3 (each within the scatter of the next, the first and the last beyond it); then compound 1.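

In this assay, the change from phenyl to 4-methoxyphenyl gives a number 23.3 percentage points lower from compound 1 to compound 4 (beyond the scatter) and so a stronger effect at the concentration tested. This is the first step shown that starts from hydrogen at this place, on an aromatic carbon para to a large group; the earlier step, a number 10.5 percentage points higher from compound 2 to compound 3 (beyond the scatter), only exchanged one substituent for another in a different series, and it showed nothing about the ring without a substituent. The result therefore shows that, on the core of compound 1, adding methoxy at this place is enough to move the number beyond the scatter, though nothing given here accounts for that shift.

The compounds shown leave open whether methoxy in place of hydrogen has a similar effect in the series of compound 2 and compound 3, or whether fluoro or methyl at this place on the core of compound 1 would move the number as far. They also leave open what an amine, a carboxylic acid or a longer chain such as ethoxy would do at the same place.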